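The source may report more compounds than this note shows. Statements on the series, on what has been measured and on what is new or still open speak of the compounds shown alone.

Compound 3, `O=C(CNC(=O)c1ccc(C#Cc2ccccc2)cc1)NO`, carries a (hydroxycarbamoyl)methyl group on an amide-type nitrogen of the shared core. In a physicochemical assay for lipophilicity (on this read-out lower numbers stand for lower lipophilicity and higher numbers for higher lipophilicity), compound 3 gives 3. Compound 1, `CSC[C@H](NC(=O)c1ccc(C#Cc2ccccc2)cc1)C(=O)NO`, gives 3 in this assay, and the step of no change at the digits printed from compound 1 to compound 3 (within the scatter) lies within the scatter, so compound 3 stands level with compound 1. Compound 2, `CC(NC(=O)c1ccc(C#Cc2ccccc2)cc1)C(=O)NO`, is reported in this assay only as a limit of > 3, not as a number. The step of a number no higher from compound 2 to compound 3 (the limit leaves the size open) therefore has an open size.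

Compound 4, `CC(C)(NC(=O)c1ccc(C#Cc2ccccc2)cc1)C(=O)NO`, is not yet measured. It differs from compound 3 in one place: 1-(hydroxycarbamoyl)-1-methylethyl in place of (hydroxycarbamoyl)methyl on an amide-type nitrogen. Compound 2 also carries a methyl on the saturated chain carbon bound to the amide-type nitrogen and the carbonyl carbon, so the step of a number no higher from compound 2 to compound 3 (the limit leaves the size open) is the one that bears on this change, and it ends at the limit of > 3 in this assay, at which 1 of the 3 values shown sits. Compound 4 goes further along the same line, so a rise beyond the scatter is expected, with an estimated step of a number 0.40 log units higher from compound 3 to compound 4 (beyond the scatter) in this assay. Compound 4 is estimated at 3.4, within a range from 3 to 3.9.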

Compound 4, distribution coefficient: 3
Estimate against measurement, compound 4: 0.40 log units above; low and high end bracket the measured number.
By their numbers in this assay, from the lowest: compounds 1, 3 and 4 (each within the scatter of the next).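

Putting 1-(hydroxycarbamoyl)-1-methylethyl in place of (hydroxycarbamoyl)methyl on an amide-type nitrogen gives no change at the digits printed from compound 3 to compound 4 (within the scatter) in this assay and nothing more can be read from this change. The group of compound 4 also matches the sulfur-bearing group of compound 1, with no change at the digits printed from compound 1 to compound 4 (within the scatter), which makes three different groups at this place that cannot be told apart on this read-out. Steps with compound 2 at one end (a number no higher from compound 2 to compound 4 (the limit leaves the size open)) cannot be read, as that compound is reported only as a limit: the limit of > 3 in this assay, at which 1 of the 4 values shown sits.

As far as these compounds go, whether an amine, a carboxylic acid or a longer chain at this place on the amide-type nitrogen would move the number beyond the scatter stays open. From the compounds shown here alone, how compound 2 truly stands against the other three compounds also stays open.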